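The source may hold more compounds than are shown below. What is called first, only, known or untested is meant among the compounds shown, and "the series" means these compounds.

Of the compounds shown here, three have been measured in a physicochemical assay for metabolic stability, read by HPLC; on this read-out lower numbers stand for a shorter-lived compound and higher numbers for a longer-lived compound. Compound 1 `O=c1ccn([C@H]2CC[C@@H](COP(=O)(O)Oc3ccncc3)O2)c(=O)[nH]1` gives 23.6 h; compound 2 `Cc1cn([C@H]2C[C@H](N=[N+]=[N-])[C@@H](COP(=O)(O)Oc3ccc(Br)cc3)O2)c(=O)[nH]c1=O` gives 7.97 h; compound 3 `Nc1ncnc2c1ncn2[C@H]1CC[C@@H](COP(=O)(O)Oc2cccnc2)O1` gives 64.2 h. Compound 2 stands lowest of the three: compound 1 lies above it beyond the scatter, and compound 3 lies further above it, also beyond the scatter. No two of these three differ in only one place, so their numbers show where each compound stands and not what any single change does.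

The account now turns from compound 2 to compound 4 `Cc1cn([C@H]2C[C@H](N=[N+]=[N-])[C@@H](COP(=O)(O)Oc3ccc(Cl)cc3)O2)c(=O)[nH]c1=O`, which has not yet been measured in this assay. The difference between the two is chloro in place of bromo on an aromatic carbon. Among the compounds with values here, the halogen is exchanged while its place is kept, and nothing among the measured compounds traces such an exchange. The step of a 1.1-fold higher number from compound 2 to compound 4 (0.03 log units; within the scatter) is expected to lie within the scatter, in no clear direction. The half-life of compound 4 is estimated at 8.5 h, between 4.5 h and 16 h.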

Compound 4, half-life: 5.5 h
The estimate for compound 4 lay 1.5-fold (0.19 log units) above the measured number; the range from low to high includes it.
By their numbers in this assay, from the lowest: compounds 4 and 2 (each within the scatter of the next); then compound 1; then compound 3.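

Within the data shown here, the exchange of bromo for chloro on an aromatic carbon, para to a large group, gives the first comparison in which only one place differs: in this assay it reads as a 1.4-fold lower number from compound 2 to compound 4 (0.16 log units; within the scatter) and so leaves the half-life unchanged within the scatter. At this position of the shared core, these two halogens therefore cannot be told apart on this read-out. No measurement at hand offers a reason for this result.

One halogen exchanged for another says little about what an amine, a carboxylic acid or a methoxy group would do at the same place, or about an unsubstituted phenyl ring. As far as these compounds go, whether the same exchange would also fall within the scatter on a different core also remains open.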